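Methylating a Phenol: Compound 2 to Compound 4

This account rests on a few compounds, and the source may have more. Where it says the series, first, only, none or still open, it means among the compounds named here.

Three related cinnamate esters have been measured so far in a functional assay on H266 cells (Homo sapiens) for cytotoxicity, read by resazurin assay, with a stated time of 72 h; a higher number here means a weaker inhibitor, a lower number a stronger inhibitor. For the measured compounds named here, compound 1 `COc1cc(/C=C/C(=O)OC(C)CCOc2no[n+]([O-])c2S(=O)(=O)c2ccccc2)ccc1O` is the only one that gives a number: in this assay compound 1 reaches 430 nM. Compound 2 `O=C(/C=C/c1ccc(OCCCCCO[N+](=O)[O-])c(O)c1)OCCCCCO[N+](=O)[O-]` stops at the edge of what this assay can report: compound 2 shows > 50000 nM, which is a limit and not a number. Compound 3 `COc1cc(/C=C/C(=O)Oc2ccc(OCc3c(-c4ccccc4)no[n+]3[O-])cc2)ccc1O` likewise gives only a limit, with compound 3 at > 50000 nM. On the values shown, compound 2 therefore stands among the weakest, at the limit of > 50000 nM in this assay, at which 2 of the 3 values shown sit.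

Compound 4 `COc1cc(/C=C/C(=O)OCCCCCO[N+](=O)[O-])ccc1OCCCCCO[N+](=O)[O-]` differs from compound 2 in a single place: methyl in place of hydrogen on an oxygen on an aromatic ring, read one bond further out, hydroxy to methoxy. Going by the values given here, no measured pair of compounds differs in only one place, so nothing measured here shows how large such a step usually is. Compound 1 also carries a methoxy on its aromatic ring and gives a number, but it differs from compound 4 in many other places and cannot speak for this step.

Compound 2 starts at a limit, and the step from compound 2 to compound 4 is expected to be small, about a step that the limit leaves unreadable from compound 2 to compound 4, with no clear direction. Compound 4 is therefore expected near 80000 nM, somewhere between 10000 nM and 500000 nM, most likely again reported only as a limit.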

Compound 4, half-maximal inhibitory concentration: > 50000 nM
Compound 4 gave a limit, no number; the forecaster's own chance of this, stated with the estimate: 75%; the middle value lies beyond the limit too.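

Compound 2 and compound 4 each give only a limit in this assay, so neither the size nor the direction of the step from hydroxy to methoxy can be read. The compounds shown leave open whether this single change affects cytotoxicity at all; answering that would take a real number on both sides.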